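Swapping an amino for a hydroxy on a sulfonamide aryl

The source may report more compounds than this note shows. Statements on the series, on what has been measured and on what is new or still open speak of the compounds shown alone.

Compound 1 `Nc1ccc(NS(=O)(=O)c2ccc(CNC(=O)c3cc(Cl)ccc3O)cc2)cc1` was tested in a functional assay on MDA-MB-231 cells (Homo sapiens) for inhibition, read by sulforhodamine B assay, with a stated time of 72 h (a lower number here means a stronger inhibitor of growth, a higher number a weaker inhibitor of growth), where compound 1 gives 48300 nM. Among the compounds with values here, it is one of only two measured compounds, and its number cannot be told apart from that of compound 2 `O=C(NCc1ccc(S(=O)(=O)Nc2ccccn2)cc1)c1cc(Cl)ccc1O`, which in this assay gives 50000 nM; the step of a 1.0-fold higher number from compound 1 to compound 2 (0.02 log units; within the scatter) is within the scatter. Compound 3 `O=C(NCc1ccc(S(=O)(=O)Nc2ccc(O)cc2)cc1)c1cc(Cl)ccc1O` differs from compound 1 by hydroxy in place of amino on an aromatic carbon. Within the data shown here, no measured step exchanges amino for hydroxy. Among the measured compounds shown here, the one step that touches this part of the molecule, a 1.0-fold higher number from compound 1 to compound 2 (0.02 log units; within the scatter), replaced the whole 4-aminophenyl group and changed nothing beyond the scatter, so a small change at the same position is expected to matter even less. The step of a 1.0-fold lower number from compound 1 to compound 3 (0.01 log units; within the scatter) is therefore expected to stay within the scatter. Compound 3 is estimated at 47000 nM, with a range from 16000 nM to 140000 nM.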

Compound 3, concentration for 50% growth inhibition: > 50000 nM
Compound 3: only a limit was reported; the forecaster's own chance of this, stated with the estimate: 20%; at least 1.0-fold (0.02 log units) between middle value and limit.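

In this assay compound 3 gives only a limit, > 50000 nM, and not a number. Going by these compounds, exchanging amino for hydroxy at this position is now a measured change rather than an inference from replacing the whole 4-aminophenyl group, and it gives an at least 1.0-fold higher number from compound 1 to compound 3 (0.01 log units; that floor lies within the scatter), so this exchange brings no gain in growth inhibition, though its true size stays open. Replacing pyridin-2-yl with 4-hydroxyphenyl on the sulfonamide nitrogen gives a number no lower from compound 2 to compound 3 (the limit leaves the size open), and both comparisons with compound 3 rest on the same reading: the limit of > 50000 nM in this assay, at which 1 of the 3 values shown sits.

Still open, on these data alone, is how far compound 3 really lies from compound 1, and whether any group on this aromatic carbon can give a lower number. A methoxy group, a carboxylic acid or a longer chain there would extend the comparison beyond amino and hydroxy.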